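This account rests on a few compounds, and the source may have more. Where it says the series, first, only, none or still open, it means among the compounds named here.

Of the compounds shown here, three built on one shared core have been measured in an assay on isolated protein (Oryctolagus cuniculus) with Thromboxane-A synthase (Homo sapiens) as the target, tested at 1 uM; a lower number here means less inhibition, a higher number more inhibition at the concentration tested (going by the name of the read-out). Compound 1 `C=CCn1nc(-c2cccnc2)c2ccccc2c1=O` gives 70% there. Compound 2 `O=c1c2ccccc2c(-c2cccnc2)nn1Cc1ccccc1` gives 97% in this assay, the highest of the three numbers, and compound 3 `COC(=O)c1ccc(Cn2nc(-c3cccnc3)c3ccccc3c2=O)cc1` gives 95%, which sits within the scatter of compound 2. The step of a number 27 percentage points higher from compound 1 to compound 2 (beyond the scatter) lies beyond the scatter, while the step of a number 2 percentage points lower from compound 2 to compound 3 (within the scatter) does not. Compound 4 `O=C(O)Cn1nc(-c2cccnc2)c2ccccc2c1=O` differs from compound 2 by carboxy in place of phenyl on a saturated chain carbon bound to an aromatic nitrogen. Among the compounds with values here, the step from compound 1 to compound 2 bears on this change, since the phenyl that entered there leaves here, and no measured compound carries a carboxy at this place. Compound 4 is therefore expected to give back part of that gain, a number 37 percentage points lower from compound 2 to compound 4 (beyond the scatter), with an estimate of 60% ranging from 35% to 85%.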

Compound 4, a percentage reported as inhibition, at one concentration (the size of the read-out at that concentration, not a potency): 13%
Compound 4: the middle estimate sits 47 percentage points above what was measured; the whole stated range lies above it.
By their numbers in this assay, from the lowest: compound 4; then compound 1; then compounds 3 and 2 (each within the scatter of the next).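

Until now this position had carried only carbon groups, and the read-out had stayed high; the carboxy shows that the change at this place can nearly abolish inhibition in this assay, with a number 84 percentage points lower from compound 2 to compound 4 (beyond the scatter). The loss does not depend on phenyl as the starting point, since the vinyl comparison also falls, with a number 57 percentage points lower from compound 1 to compound 4 (beyond the scatter). Nothing available gives a reason for this drop.

From the compounds shown here alone, it remains open whether an amide or methyl ester here would behave like the carboxy. Also open, going by these compounds, is whether a longer chain ending in a carboxylic acid, or a carboxylic acid on an aromatic carbon of the benzyl, would recover inhibition.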